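The source may report more compounds than this note shows. Statements on the series, on what has been measured and on what is new or still open speak of the compounds shown alone.

In an ADME assay on Caco-2 cells (Homo sapiens) for permeability, in the apical to basolateral direction (a lower number here means that the compound crosses the layer more slowly, a higher number that the compound crosses the layer faster), compound 1 `Cc1nc(NC(=O)C(C)(C)CC(F)(F)F)sc1-c1ccc(N)nc1` gives 41 10^-6 cm/s, compound 2 `Cc1nc(NC(=O)CN(Cc2ccccc2)C(=O)c2ccncc2)sc1-c1ccc(N)nc1` gives 2.1 10^-6 cm/s, and compound 3 `Cc1nc(NC(=O)C2(C)CCCCC2)sc1-c1ccc(N)nc1` gives 20 10^-6 cm/s. Compound 3 therefore stands second highest of the three numbers shown: compound 1 lies nearest to it, and the one step measured so far, a 2.1-fold lower number from compound 1 to compound 3 (0.31 log units; beyond the scatter), separates them; compound 2 lies furthest from it, with a much lower number, though no single-point step connects compound 2 to compound 3.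

Compound 4 `CO[C@H]1CC[C@@H](C(=O)Nc2nc(C)c(-c3ccc(N)nc3)s2)CC1` has not yet been measured in this assay. It differs from compound 3 by one change, (4-methoxycyclohexyl in place of 1-methylcyclohexyl on a carbonyl carbon). Among the compounds with values here, no measured step bears directly on this exchange: the only step available, from compound 1 to compound 3, concerns a different group on the same carbonyl carbon and was itself modest. Since the new group brings one hydrogen-bond acceptor where the old one had none, the step in this assay is expected to be downward and of modest size, a 1.7-fold lower number from compound 3 to compound 4 (0.22 log units; within the scatter), though a result within the scatter of compound 3 cannot be excluded. Compound 4 is accordingly estimated at 12 10^-6 cm/s, with a plausible range from 5 10^-6 cm/s to 25 10^-6 cm/s.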

Compound 4, apparent permeability in the Caco-2 assay: 18 10^-6 cm/s
Compound 4: the middle estimate sits 1.5-fold (0.18 log units) below what was measured; the measured number falls inside the stated range.
By their numbers in the Caco-2 assay, from the lowest: compound 2; then compounds 4 and 3 (each within the scatter of the next); then compound 1.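

At this position, on a carbonyl carbon whose other neighbour is an amide-type nitrogen, the Caco-2 assay does not tell 4-methoxycyclohexyl from 1-methylcyclohexyl: a 1.1-fold lower number from compound 3 to compound 4 (0.05 log units; within the scatter). Thus the hydrogen-bond acceptor that enters with the methoxy group leaves no readable mark on this number, whereas in a physicochemical assay for lipophilicity, at pH 7.4 (a lower number here means a more polar compound, a higher number a more lipophilic compound), the same exchange does register, so the two read-outs part ways for this pair: the measured distribution coefficient of compound 3, 3.8, and of compound 4, 2.8, a number 1.00 log units lower (beyond the scatter) In the physicochemical assay compound 3 gives 3.8 and compound 4 gives 2.8. In the Caco-2 assay both cyclohexyl groups stand apart from the 3,3,3-trifluoro-1,1-dimethylpropyl group, with a 2.3-fold lower number from compound 1 to compound 4 (0.36 log units; beyond the scatter) and a 2.1-fold lower number from compound 1 to compound 3 (0.31 log units; beyond the scatter).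

The compounds shown leave open whether the number in the Caco-2 assay would also hold with a hydroxyl group or an amine on the cyclohexyl ring in place of the methoxy group, since each of the two groups compared here has no hydrogen-bond donor. As far as these compounds go, only one arrangement of the two defined stereocentres of 4-methoxycyclohexyl appears among them, so what the other arrangement would give in either the Caco-2 assay or the physicochemical assay also remains open.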